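Methoxy on the arylidene ring of a spirocyclic oxindole core

This account rests on a few compounds, and the source may have more. Where it says the series, first, only, none or still open, it means among the compounds named here.

Measured compounds:
- compound 1 `CN1C/C(=C\c2ccccc2)C(=O)[C@]2(C1)[C@@H](c1ccccc1)CN(C)[C@@]21C(=O)Nc2ccccc21`: 65.1%
- compound 2 `CN1C/C(=C\c2ccccc2)C(=O)[C@]2(C1)[C@@H](c1ccccc1)CN(C)[C@@]21C(=O)N(C)c2ccccc21`: 26.5%
- compound 3 `CN1C/C(=C\c2ccc(Cl)cc2)C(=O)[C@]2(C1)[C@@H](c1ccc(Cl)cc1)CN(C)[C@@]21C(=O)N(C)c2ccccc21`: 49.3%

Three compounds share the core of compound 1 and were tested in a functional assay on the whole organism (strain Wister albino) for inhibition, with Rattus norvegicus as the target, read by paw edema, with stated times of 1 h and 24 h, at a dose of 50 mg/kg by the intraperitoneal route; on this read-out lower numbers stand for less inhibition and higher numbers for more inhibition at the one dose given (going by the name of the read-out). Compound 1 gives 65.1% and stands highest of the three numbers. Compound 3 comes nearest, with 49.3%, and compound 2 lies furthest, with 26.5%. Within the data shown here, the one step that changes a single place, a number 38.6 percentage points lower from compound 1 to compound 2 (beyond the scatter), is large and beyond the scatter. Compounds 2 and 3 differ in more than one place, so their two values are only set side by side.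

Compound 4 `COc1ccc(/C=C2\CN(C)C[C@@]3(C2=O)[C@@H](c2ccccc2)CN(C)[C@@]32C(=O)Nc3ccccc32)cc1` is not yet measured. It differs from compound 1 by methoxy in place of hydrogen on an aromatic carbon. Among the measured compounds shown here, no measured step touches that aromatic carbon, so nothing here bears directly on the change; the only large step concerns the amide-type nitrogen in a ring, a different place. The expectation for compound 4 is therefore a step within the scatter, a number 3.1 percentage points lower from compound 1 to compound 4 (within the scatter), with a wide range. Compound 4 is estimated to give 62%, between 45% and 78%.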

Compound 4, a percentage reported as inhibition, in the whole organism at one dose (the size of the read-out at that dose, not a potency): 52.9%
Compound 4: the middle estimate sits 9.1 percentage points above what was measured, and the stated range covers the measured number.
By their numbers in this assay, from the lowest: compound 2; then compounds 3 and 4 (each within the scatter of the next); then compound 1.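

The change from phenyl to 4-methoxyphenyl shows that this aromatic carbon matters in this assay: methoxy in place of hydrogen gives a number 12.2 percentage points lower from compound 1 to compound 4 (beyond the scatter). This makes it a second place on the core of compound 1 where a single change moves the number, with a modest step here and a large one at the amide-type nitrogen, a number 38.6 percentage points lower from compound 1 to compound 2 (beyond the scatter). Nothing available bears on what lies behind the step at this aromatic carbon.

From the compounds shown here alone, what a hydroxy group, an amine or a longer ethoxy chain would give at this place stays open, so the step cannot yet be tied to methoxy in particular. Also open, going by these compounds, is whether methoxy at this place would bring a similar step on compound 2, which carries methyl on the amide-type nitrogen.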